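Amide side chain on compound 3: expected effect

A few compounds are considered here, and "the series" means these few. Any claim that something is new, unique, unknown or untested is made for them only; others in the source may bear on it.

In a toxicity assay on HeLa cells (Homo sapiens) for cytotoxicity, read by CCK-8 assay, with stated times of 16 h and 24 h (a higher number here means a weaker inhibitor, a lower number a stronger inhibitor), compound 1 (`COc1ccc(C2=[N+]3C(=Nc4c(-c5ccccc5)c5c(n4[B-]3(F)F)-c3ccc(OCC(=O)O)cc3CC5)C(c3ccccc3)=C2I)cc1`) gives 56 nM, compound 2 (`COc1ccc(C2=[N+]3C(=Nc4c(-c5ccccc5)c5c(n4[B-]3(F)F)-c3ccc(OCC(=O)N[C@@H](CC(=O)O)C(=O)O)cc3CC5)C(c3ccccc3)=C2I)cc1`) gives 21 nM and compound 3 (`COc1ccc2c(c1)CCc1c(-c3ccccc3)c3n(c1-2)[B-](F)(F)[N+]1=C(c2ccc(OCC(=O)O)cc2)C(I)=C(c2ccccc2)C1=N3`) gives 274 nM. Compound 3 thus has the highest of the three numbers, and both other values lie beyond the scatter from it.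

Compound 4 (`COc1ccc2c(c1)CCc1c(-c3ccccc3)c3n(c1-2)[B-](F)(F)[N+]1=C(c2ccc(OCC(=O)N[C@@H](CCC(=O)O)C(=O)O)cc2)C(I)=C(c2ccccc2)C1=N3`) is the next point, and it differs from compound 3 at one place: (1,3-dicarboxypropyl)amino in place of hydroxy on a carbonyl carbon. In words, (1,3-dicarboxypropyl)amino stands in place of hydroxy on a carbonyl carbon.

Within the data shown here, only one measured step bears on this change. Placing (1,2-dicarboxyethyl)amino in place of hydroxy on a carbonyl carbon gave a 2.7-fold lower number from compound 1 to compound 2 (0.43 log units; beyond the scatter). That is a modest step beyond the scatter, but it is a single precedent, taken on a different compound and with a different entering group. Among the measured compounds shown here, no measurement yet exists for (1,3-dicarboxypropyl)amino.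

A lower number of similar modest size is therefore expected in this assay, with an estimated change of a 2.6-fold lower number from compound 3 to compound 4 (0.42 log units; beyond the scatter). The range is kept wide, and its upper end allows for almost no change. For compound 4 the estimated value is 105 nM, within an expected range of 35 nM to 270 nM.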

Compound 4, half-maximal inhibitory concentration in the HeLa assay: 119 nM
Estimate against measurement, compound 4: 1.1-fold (0.05 log units) below, within the range that was stated.
By their numbers in the HeLa assay, from the lowest: compound 2; then compound 1; then compound 4; then compound 3.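

In the HeLa assay, (1,3-dicarboxypropyl)amino in place of hydroxy on this carbonyl carbon gives a 2.3-fold lower number from compound 3 to compound 4 (0.36 log units; beyond the scatter). Among these compounds, the side-chain effect therefore no longer rests on the single pair of compound 1 and compound 2: two different dicarboxyalkylamino groups, on two different parent compounds, each give a modest step beyond the scatter toward a lower number, and neither pair goes against this. In a physicochemical assay for solubility, in phosphate buffer (on this read-out lower numbers stand for lower solubility and higher numbers for higher solubility), compound 3 gives 21800 nM and compound 4 gives 110000 nM. The change also gives the series its first direct link between this amide and solubility, since in the physicochemical assay the same replacement moves the number upward, toward higher solubility: the measured solubility of compound 3, 21800 nM, and of compound 4, 110000 nM, a 5.0-fold higher number (0.70 log units; beyond the scatter)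

One pair cannot show whether the lower number in the HeLa assay follows from the higher solubility or is a separate effect of the side chain, so no cause for the lower number can be given. As far as these compounds go, it also remains open whether the carboxy groups of the side chain are needed for either effect, a question that an amide ending in a primary amine, or in a longer chain carrying a single carboxylic acid, would address at this carbonyl carbon.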